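Anilino halogen moved on the shared core

The source may report more compounds than this note shows. Statements on the series, on what has been measured and on what is new or still open speak of the compounds shown alone.

In a functional assay on PC-3 cells (Homo sapiens) for inhibition, read by MTT assay, with a stated time of 72 h (on this read-out higher numbers stand for weaker inhibition and lower numbers for stronger inhibition), compound 2 `C=CC(=O)Nc1cccc(NC(=O)CSc2nc(Nc3ccccc3Br)c3ccccc3n2)c1` gives 17100 nM, the upper of the two numbers measured, though its gap to compound 1 is within the scatter. Compound 1 `C=CC(=O)Nc1cccc(NC(=O)CSc2nc(Nc3ccccc3Cl)c3ccccc3n2)c1` gives 14400 nM, and the step of a 1.2-fold higher number from compound 1 to compound 2 (0.07 log units; within the scatter) stays within the scatter. Compound 3 `C=CC(=O)Nc1cccc(NC(=O)CSc2nc(Nc3cccc(F)c3)c3ccccc3n2)c1` differs from compound 2 by 3-fluorophenyl in place of 2-bromophenyl on a nitrogen on an aromatic ring. Going by the values given here, the only measured step bears on the halogen itself, not on where it sits on the ring, so the move to a 3-fluorophenyl has no direct precedent; no step beyond the scatter is expected in this assay. Compound 3 is estimated at 15000 nM, with a range from 5000 nM to 45000 nM. The step this estimate implies, a 1.1-fold lower number from compound 2 to compound 3 (0.06 log units; within the scatter), is expected to remain within the scatter.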

Compound 3, half-maximal inhibitory concentration: 5370 nM
Compound 3: the middle estimate sits 2.8-fold (0.45 log units) above what was measured; low and high end bracket the measured number.
By their numbers in this assay, from the lowest: compound 3; then compounds 1 and 2 (each within the scatter of the next).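

On the group on this nitrogen in this assay, 3-fluorophenyl gives a 3.2-fold lower number from compound 2 to compound 3 (0.50 log units; beyond the scatter) and a 2.7-fold lower number from compound 1 to compound 3 (0.43 log units; beyond the scatter), both modest but beyond the scatter, whereas exchanging bromo and chloro at the 2-substituted phenyl did not leave the scatter. This change therefore shows that the aryl group at this place can shift the number. No measured data account for the shift. The halogen and its place on the ring change together here, so their contributions cannot be separated. Also open, on these data alone, is how an unsubstituted phenyl or a methoxyphenyl would compare.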